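Amide Nitrogen Substitution in a Sulfonamide Series

The source may report more compounds than this note shows. Statements on the series, on what has been measured and on what is new or still open speak of the compounds shown alone.

Measured compounds:
Compound 1, `CC(=O)c1ccc(NC(=O)c2nc(-c3ccccc3)n(-c3ccc(S(N)(=O)=O)cc3)n2)cc1`: 68%
Compound 2, `NC(=O)c1nc(-c2ccccc2)n(-c2ccc(S(N)(=O)=O)cc2)n1`: 48%

Going by the values given here, in a functional assay on the whole organism for inhibition, with Rattus norvegicus as the target, read by paw edema, with stated times of 30 min and 2 h, at a dose of 0.28 mmol/kg by the oral route (on this read-out higher numbers stand for more inhibition at the one dose given (going by the name of the read-out) and lower numbers for less inhibition), compound 2 gives 48%, the lower of the two numbers measured so far; compound 1 gives 68%. Among the compounds with values here, the single measured step, a number 20 percentage points lower from compound 1 to compound 2 (beyond the scatter), shows that removing an aryl substituent from the amide nitrogen lowers inhibition beyond the scatter. Compound 3, `NS(=O)(=O)c1ccc(-n2nc(C(=O)NC3CCCCC3)nc2-c2ccccc2)cc1`, has not been measured. It differs from compound 2 by cyclohexyl in place of hydrogen on an amide-type nitrogen. The step from compound 1 to compound 2 bears on this change only in that both concern substitution on the same amide nitrogen, so it gives a direction but not a size for an alkyl group. A modest rise is therefore expected, smaller than the measured step; the estimated step is a number 10 percentage points higher from compound 2 to compound 3 (within the scatter). Compound 3 is expected to give 58%, with a range from 42% to 72%.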

Compound 3, a percentage reported as inhibition, in the whole organism at one dose (the size of the read-out at that dose, not a potency): 43%
Compound 3: middle estimate off by 15 percentage points, on the high side, within the range that was stated.
By their numbers in this assay, from the lowest: compounds 3 and 2 (each within the scatter of the next); then compound 1.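

In this assay, cyclohexyl in place of hydrogen on the amide-type nitrogen gives a number 5 percentage points lower from compound 2 to compound 3 (within the scatter), so a substituent at this position does not by itself raise the read-out beyond the scatter. With cyclohexyl in place of 4-acetylphenyl, the same position gives a number 25 percentage points lower from compound 1 to compound 3 (beyond the scatter), which leaves compound 1 as the only one of the three that stands apart and ties its higher number to the 4-acetylphenyl group rather than to substitution as such. Nothing available gives a reason for this difference between the two groups.

Still open, from the compounds shown here alone, is which part of the 4-acetylphenyl group matters, a question that an unsubstituted phenyl group on the same nitrogen would address. The compounds shown also leave open how a benzyl group or a short chain such as methyl would behave there.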